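Methoxy additions on the aryl ring of a dienone series

The source may report more compounds than this note shows. Statements on the series, on what has been measured and on what is new or still open speak of the compounds shown alone.

Measured so far in a functional assay on Hep cells (Homo sapiens) for cytotoxicity, read by sulforhodamine B assay, with a stated time of 48 h; a higher number here means a weaker inhibitor, a lower number a stronger inhibitor:
compound 1 `CC1=C(/C=C/C(=O)/C=C/c2ccccc2)C(C)(C)CCC1` gives 62200 nM
compound 2 `COc1ccccc1/C=C/C(=O)/C=C/C1=C(C)CCCC1(C)C` gives 38900 nM
compound 3 `COc1ccc(/C=C/C(=O)/C=C/C2=C(C)CCCC2(C)C)cc1OC` gives 72400 nM

All three numbers sit within the usual scatter of one another, so no order among compound 1, compound 2 and compound 3 can be read from them. Among the measured compounds shown here, the one counted step is a 1.6-fold lower number from compound 1 to compound 2 (0.20 log units; within the scatter), the change being (methoxy in place of hydrogen on an aromatic carbon). How the core of compound 3 differs from the core of compound 1 is not broken down here.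

Compound 4 `COc1cc(/C=C/C(=O)/C=C/C2=C(C)CCCC2(C)C)cc(OC)c1OC` is not yet measured in this assay. It differs from compound 3 by methoxy in place of hydrogen on an aromatic carbon. For the measured compounds named here, this is the same kind of change as the one from compound 1 to compound 2, but not the same: in compound 2 the entering group sits ortho to a large group, whereas in compound 4 it sits ortho to a methoxy group, meta to a large group and meta to a methoxy group.

The expectation for compound 4 rests on the earlier step, which stayed within the scatter, and on the value of compound 3, which is 72400 nM. The step expected from the same kind of change is a 1.2-fold lower number from compound 3 to compound 4 (0.08 log units; within the scatter). Compound 4 is therefore estimated at 60000 nM in this assay, with a range from 30000 nM to 130000 nM.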

Compound 4, half-maximal inhibitory concentration: 45500 nM
Compound 4: the middle estimate sits 1.3-fold (0.12 log units) above what was measured; measured number inside the range.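

In this assay, methoxy in place of hydrogen on an aromatic carbon gives a 1.6-fold lower number from compound 3 to compound 4 (0.20 log units; within the scatter), and the step reads the same on the two cores: the same change on two cores in this assay, a 1.6-fold lower number (0.20 log units; within the scatter) from compound 1 to compound 2 and a 1.6-fold lower number (0.20 log units; within the scatter) from compound 3 to compound 4, 1.0-fold (0.00 log units) apart, within the scatter of two such steps

Among the compounds shown here, each step lies within the scatter, so what carries from the core of compound 1 to the core of compound 3 is only that this change leaves no readable effect on either, and the matching size of the two steps cannot be taken as a real, transferable gain. The comparison also rests on just two pairs, and the entering methoxy of compound 4 sits ortho to a methoxy group, meta to a large group and meta to a methoxy group, whereas the entering methoxy of compound 2 has a different place on a ring with no other methoxy, so the two steps do not test one position under like surroundings.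

Whether an amine, a carboxylic acid or a longer alkoxy chain on the aromatic ring would give a step beyond the scatter stays open, since the compounds shown carry only hydrogen or methoxy there. Going by these compounds, every number here comes from this assay, so how the same change reads in any other assay also stays open.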